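A few compounds are considered here, and "the series" means these few. Any claim that something is new, unique, unknown or untested is made for them only; others in the source may bear on it.

Measured compounds:
Compound 1 `Cc1ccc(C(=O)Nc2sc3c(c2C(N)=O)CCN(Cc2c(Cl)cccc2Cl)C3)cc1` gives 47400 nM in a functional assay on HeLa cells (Homo sapiens) for antiproliferative activity, with a stated time of 24 h; on this read-out higher numbers stand for weaker inhibition and lower numbers for stronger inhibition.
Compound 2 `NC(=O)c1c(NC(=O)c2ccccc2Cl)sc2c1CCN(C(=S)Nc1cccc3ccccc13)C2` gives 30800 nM in this assay.

Compound 2 and compound 1 are the only two measured here, and their two numbers lie within the scatter of each other, so no order between them can be read from the data. Compound 3 `NC(=O)c1c(NC(=O)c2ccccc2Cl)sc2c1CCN(C(=S)Nc1ccccc1-c1ccccc1)C2` has not yet been measured. It differs from compound 2 in one place: 2-phenylphenyl in place of naphthalen-1-yl on an amide-type nitrogen. Within the data shown here, no step between measured compounds is available to show how this sort of exchange behaves on this read-out, so the expectation rests on the pair of weak values alone. Given that compound 2 gives 30800 nM, the step from compound 2 to compound 3 is expected to be small, a 1.0-fold lower number from compound 2 to compound 3 (0.01 log units; within the scatter), not beyond the scatter in either direction. Compound 3 is therefore estimated at 30000 nM, with a range from 10000 nM to 90000 nM.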

Compound 3, half-maximal inhibitory concentration: 24000 nM
The estimate for compound 3 lay 1.3-fold (0.10 log units) above the measured number, within the range that was stated.
By their numbers in this assay, from the lowest: compounds 3, 2 and 1 (each within the scatter of the next).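

In this assay, among these compounds, the exchange of naphthalen-1-yl for 2-phenylphenyl on an amide-type nitrogen gives a 1.3-fold lower number from compound 2 to compound 3 (0.11 log units; within the scatter) and is the first step that can be read at this position. On this read-out, the two groups, each with two six-membered aromatic rings of carbon only, cannot be told apart, even though 2-phenylphenyl is the larger by heavy atoms and joins its rings differently. Nothing on hand bears on why the step is so small.

The compounds shown leave open whether any group at this position can move the number beyond the scatter, for instance a pyridine ring, a carboxylic acid or a plain butyl chain in place of these carbon-only aromatic groups. They also leave open what a carbonyl would do in place of the thiocarbonyl.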